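Lengthening a Chain on a Quinoline-Free Core, Step by Step

A few compounds are considered here, and "the series" means these few. Any claim that something is new, unique, unknown or untested is made for them only; others in the source may bear on it.

Compound 1 `CCc1cc2ccccc2nc1-c1cc(-c2ccccc2)no1` was tested in a functional assay on A549 cells (Homo sapiens) for inhibition, read by MTT assay, with a stated time of 24 h; a higher number here means a weaker inhibitor, a lower number a stronger inhibitor. In this assay compound 1 gives only a limit, > 100000 nM, not a number (the limit of > 100000 nM in this assay, at which 1 of the 3 values shown sits). Compound 2 `CCCc1cc2ccccc2nc1-c1cc(-c2ccccc2)no1` carries methyl in place of hydrogen on a saturated chain carbon, two bonds along the chain from an aromatic carbon and in this assay compound 2 gives 52500 nM, a step of an at least 1.9-fold lower number from compound 1 to compound 2 (0.27 log units; that floor lies within the scatter). Compound 3 `CCCCc1cc2ccccc2nc1-c1cc(-c2ccc(C(F)(F)F)cc2)no1` in this assay gives 9400 nM; the difference between the cores of compound 1 and compound 3 is not broken down here. Compound 4 `CCCCCc1cc2ccccc2nc1-c1cc(-c2ccc(C(F)(F)F)cc2)no1` has not yet been measured; it carries methyl in place of hydrogen on a saturated chain carbon, four bonds along the chain from an aromatic carbon. This is the same kind of change as from compound 1 to compound 2, though placed four bonds rather than two bonds along the chain from the aromatic carbon. Resting on the earlier step of an at least 1.9-fold lower number from compound 1 to compound 2 (0.27 log units; that floor lies within the scatter), the expected step is a 1.6-fold lower number from compound 3 to compound 4 (0.19 log units; within the scatter), giving an estimate for compound 4 of 6000 nM, between 2000 nM and 20000 nM.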

Compound 4, half-maximal inhibitory concentration: 28300 nM
The estimate for compound 4 lay 4.7-fold (0.67 log units) below the measured number; measured number outside the range, above it.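

In this assay, methyl in place of hydrogen four bonds along the chain from an aromatic carbon gives a 3.0-fold higher number from compound 3 to compound 4 (0.48 log units; beyond the scatter), so the weaker inhibitor here is the one with the longer chain. This change therefore did not carry over unchanged from one core to the other, even though it is the same kind of change: the same change on two cores in this assay, an at least 1.9-fold lower number (0.27 log units; that floor lies within the scatter) from compound 1 to compound 2 and a 3.0-fold higher number (0.48 log units; beyond the scatter) from compound 3 to compound 4, at least 5.7-fold (0.75 log units) apart, beyond the scatter of two such steps Compound 1 gives only a limit, so the true size of the earlier step stays unknown, and these two steps do not show whether the core or the place on the chain separates them: the limit of > 100000 nM in this assay, at which 1 of the 4 values shown sits.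

From the compounds shown here alone, whether a longer chain, such as hexyl, would push the number higher still remains open. So does the outcome of putting an amine in place of the chain.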